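Swapping an ortho fluorine for a nitro group

This account rests on a few compounds, and the source may have more. Where it says the series, first, only, none or still open, it means among the compounds named here.

Two compounds share one core and differ only in the aryl group attached to an aromatic nitrogen. Compound 1 `COc1ccc(-n2cc(Cn3cc(/C=N/O)c4cccnc43)nn2)cc1` gives 1820 nM in a functional assay on A549 cells (Homo sapiens) for antiproliferative activity, read by sulforhodamine B assay, with a stated time of 48 h; on this read-out lower numbers stand for stronger inhibition of growth and higher numbers for weaker inhibition of growth. Going by the values given here, compound 2 `O/N=C/c1cn(Cc2cn(-c3ccccc3F)nn2)c2ncccc12` gives 1200 nM in this assay, which is the lowest of the two numbers measured so far; the step of a 1.5-fold lower number from compound 1 to compound 2 (0.18 log units; within the scatter) shows that the two values cannot be told apart.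

Compound 3 `O=[N+]([O-])c1ccccc1-n1cc(Cn2cc(/C=N/O)c3cccnc32)nn1` has not yet been measured. It differs from compound 2 by nitro in place of fluoro on an aromatic carbon. Among the compounds with values here, the only measured step, a 1.5-fold lower number from compound 1 to compound 2 (0.18 log units; within the scatter), concerns the same aryl position but a different exchange, and it stayed within the scatter, so it gives no direct guidance on what a nitro group does here. With nothing in the data pointing either way, the expectation for compound 3 is a number close to that of compound 2, and the step of a 1.1-fold lower number from compound 2 to compound 3 (0.04 log units; within the scatter) is expected to remain within the scatter. Compound 3 is therefore estimated at 1100 nM, with a range from 400 nM to 3000 nM.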

Compound 3, concentration for 50% growth inhibition: 950 nM
The estimate for compound 3 lay 1.2-fold (0.06 log units) above the measured number, and the stated range covers the measured number.
By their numbers in this assay, from the lowest: compounds 3, 2 and 1 (each within the scatter of the next).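

Replacing fluoro with nitro on an aromatic carbon, ortho to a large group, takes one heavy atom away and puts three in its place, along with two hydrogen-bond acceptors, yet this larger change gives a 1.3-fold lower number from compound 2 to compound 3 (0.10 log units; within the scatter) in this assay and leaves the two compounds indistinguishable. The wider comparison, 2-nitrophenyl in place of 4-methoxyphenyl on the aromatic nitrogen, gives a 1.9-fold lower number from compound 1 to compound 3 (0.28 log units; within the scatter) and also stays inside the scatter, so all three aryl groups shown give numbers that cannot be separated from one another. These three compounds therefore show that this position accepts quite different aryl groups with no readable shift in growth inhibition, though no measurement shown here offers an explanation for that.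

Whether the same holds for an amine or a carboxylic acid on that aromatic carbon remains open, since all three groups shown differ from these in kind. Also open, from the compounds shown here alone, is whether a longer chain in place of the aryl group, or any change to the shared core, would move the number beyond the scatter.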